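A few compounds are considered here, and "the series" means these few. Any claim that something is new, unique, unknown or untested is made for them only; others in the source may bear on it.

Of the compounds shown here, two have been tested so far in a physicochemical assay for solubility; a higher number here means a more soluble compound, a lower number a less soluble compound. Compound 1, `O=C(O)c1ccc(C(=O)/C(=C\c2ccc(F)c([N+](=O)[O-])c2)S(=O)(=O)Cc2ccc(Br)cc2)cc1`, gives < 1000 ug/mL, which is a limit of the assay and not a number. Compound 2, `O=C(O)c1ccc(C(=O)/C(=C\c2cc([N+](=O)[O-])ccc2F)SCc2ccc(Br)cc2)cc1`, gives < 1000 ug/mL, which is also a limit and not a number. The whole picture so far is the limit of < 1000 ug/mL in this assay, at which 2 of the 2 values shown sit, so compound 2 has no exact place on the scale, and no order can be read between the two compounds.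

Compound 3, `O=C(O)c1ccc(C(=O)/C(=C\c2ccc([N+](=O)[O-])c(F)c2)SCc2ccc(Br)cc2)cc1`, keeps the rest of compound 2 and alters one group: 3-fluoro-4-nitrophenyl in place of 2-fluoro-5-nitrophenyl on a double-bonded chain carbon bound to a double-bonded chain carbon. The two structures have the same atoms, joined differently, with 3-fluoro-4-nitrophenyl in place of 2-fluoro-5-nitrophenyl on a double-bonded chain carbon bound to a double-bonded chain carbon. Going by the values given here, no measured pair shows what such a swap does to the read-out. The expected step that the limit leaves unreadable from compound 2 to compound 3 is estimated to stay within the usual scatter, with no direction favoured. For compound 3 the estimate is 600 ug/mL, with an expected range from 200 ug/mL to 1000 ug/mL, and the result may well arrive as a limit again.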

Compound 3, solubility: < 1000 ug/mL
Compound 3 gave a limit, no number; the forecaster's own chance of this, stated with the estimate: 85%; the middle value does not contradict the limit.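

In this assay compound 3 gives < 1000 ug/mL, which is a limit of the assay and not a number. Compound 2 also stands at a limit, so no step between compound 2 and compound 3 can be read, and all compounds shown share one limit: the limit of < 1000 ug/mL in this assay, at which 3 of the 3 values shown sit.

Going by these compounds, what 3-fluoro-4-nitrophenyl in place of 2-fluoro-5-nitrophenyl does to the read-out, and how the three compounds rank, stays open.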